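Bromo to pyrrolidin-1-yl on the chain of compound 1

This account rests on a few compounds, and the source may have more. Where it says the series, first, only, none or still open, it means among the compounds named here.

- Compound 1 `Cc1ncc([N+](=O)[O-])n1CCCCCBr`: 83 ug/mL
- Compound 2 `Cc1ncc([N+](=O)[O-])n1CCCCN1CCCCC1`: > 100 ug/mL, a limit

Going by the values given here, in an ADME assay on J774 cells (Mus musculus) for cytotoxicity, read by resazurin assay, with a stated time of 24 h (on this read-out higher numbers stand for weaker inhibition and lower numbers for stronger inhibition), compound 1 gives 83 ug/mL, the only actual number so far. Compound 3 `Cc1ncc([N+](=O)[O-])n1CCCCCN1CCCC1` carries pyrrolidin-1-yl in place of bromo on a saturated chain carbon, five bonds along the chain from an aromatic nitrogen. Among the compounds with values here, compound 2 offers the only measured guide, with an at least 1.2-fold higher number from compound 1 to compound 2 (0.08 log units; that floor lies within the scatter). In this assay a step beyond the scatter is therefore not expected, and any shift is expected towards higher numbers. The expected step is a 1.3-fold higher number from compound 1 to compound 3 (0.12 log units; within the scatter). Compound 3 is estimated at 110 ug/mL, within a range of 55 ug/mL to 220 ug/mL.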

Compound 3, half-maximal inhibitory concentration: > 100 ug/mL
Compound 3 ended at the assay's limit; the forecaster's own chance of this, stated with the estimate: 50%; the middle value does not contradict the limit.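

Pyrrolidin-1-yl in place of bromo on a saturated chain carbon, five bonds along the chain from an aromatic nitrogen, gives an at least 1.2-fold higher number from compound 1 to compound 3 (0.08 log units; that floor lies within the scatter) in this assay. A five-membered ring amine on this chain therefore also ends at the limit, as the piperidin-1-yl of compound 2 does. No comparison of the two ring amines can be read because both compounds sit at that limit: the limit of > 100 ug/mL in this assay, at which 2 of the 3 values shown sit.

Real numbers for compound 2 and compound 3 remain open. So does whether a primary amine, a carboxylic acid or a longer chain would give a number within the assay's range.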